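The compounds below may be only part of what the source reports. "The series", "measured", "known", "first", "only" and "open" are said of these compounds alone.

Working notes on the series in a functional assay on HL60/MX2 cells (Homo sapiens) for antiproliferative activity, read by MTT assay, with a stated time of 48 h; a lower number here means a stronger inhibitor, a higher number a weaker inhibitor:
- compound 1 `CN(C)CCCn1c(N)c(-c2nc3ccccc3[nH]2)c2nc(C#N)c(C#N)nc21`: 2390 nM
- compound 2 `CN(C)CCCn1c(N)c(-c2nc3ccccc3o2)c2nc(C#N)c(C#N)nc21`: 1310 nM
- compound 3 `CN(C)CCn1c(N)c(-c2nc3ccccc3s2)c2nc(C#N)c(C#N)nc21`: > 50000 nM (a limit, not a number)

Compound 3 has only a limit, (the limit of > 50000 nM in this assay, at which 1 of the 3 values shown sits).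

Compound 4 `CN(C)CCCn1c(N)c(-c2nc3ccccc3s2)c2nc(C#N)c(C#N)nc21` differs from compound 3 in the chain: (dimethylamino)methyl in place of dimethylamino on a saturated chain carbon, two bonds along the chain from an aromatic nitrogen. This is the change from 2-(dimethylamino)ethyl to 3-(dimethylamino)propyl, the chain carried by compound 1 and compound 2. For the measured compounds named here, no measured step covers this change. Going by the values given here, the one measured step, a 1.8-fold lower number from compound 1 to compound 2 (0.26 log units; within the scatter), alters the aromatic group on that longer chain and stays within the scatter. The expected step is an at least 27-fold lower number from compound 3 to compound 4 (1.44 log units; beyond the scatter), towards a lower number and beyond the scatter. For compound 4 the estimated value is 1800 nM, with an expected range of 500 nM to 8000 nM.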

Compound 4, half-maximal inhibitory concentration: 1310 nM
For compound 4 the middle estimate is 1.4-fold (0.14 log units) above the measured one; the range from low to high includes it.
By their numbers in this assay, from the lowest: compounds 2, 4 and 1 (each within the scatter of the next). At a limit, above all of these: compound 3.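

In this assay, for the compounds shown here, 3-(dimethylamino)propyl in place of 2-(dimethylamino)ethyl gives an at least 38-fold lower number from compound 3 to compound 4 (1.58 log units; beyond the scatter), the only step beyond the scatter, and so the first to show that this chain position matters. Compound 3 holds only a limit, not a number: the limit of > 50000 nM in this assay, at which 1 of the 4 values shown sits. On the 3-(dimethylamino)propyl chain, 1,3-benzothiazol-2-yl adds a third aromatic group with no separation from the other two, with no change at the digits printed from compound 2 to compound 4 (within the scatter) and a 1.8-fold lower number from compound 1 to compound 4 (0.26 log units; within the scatter).

Still open, from the compounds shown here alone, is whether a longer chain or a terminal morpholine keeps this level. Also open, going by these compounds, is whether 2-(dimethylamino)ethyl has the same effect with 1,3-benzoxazol-2-yl or 1H-benzimidazol-2-yl.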